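Replacing 4-methylphenyl with 2-bromophenyl on the shared core

The source may report more compounds than this note shows. Statements on the series, on what has been measured and on what is new or still open speak of the compounds shown alone.

Measured in a functional assay on HepG2 cells (Homo sapiens) for antiproliferative activity, read by MTT assay, with a stated time of 24 h; on this read-out higher numbers stand for weaker inhibition and lower numbers for stronger inhibition:
- compound 1 `O=[N+]([O-])c1cccc(CSc2nnc(-c3ccc4c(c3)OCCO4)n2-c2ccccc2)c1`: 49300 nM
- compound 2 `Clc1ccccc1CSc1nnc(-c2ccc3c(c2)OCCO3)n1-c1ccccc1`: 970 nM
- compound 3 `Cc1ccc(CSc2nnc(-c3ccc4c(c3)OCCO4)n2-c2ccccc2)cc1`: 56800 nM

These compounds differ only in the group on a saturated chain carbon bound to a sulfur. Compound 3 gives 56800 nM, at the high end of the three numbers, and it has company there: a 1.2-fold higher number from compound 1 to compound 3 (0.06 log units; within the scatter). The remaining value lies far lower: a 59-fold higher number from compound 2 to compound 3 (1.77 log units; beyond the scatter).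

The next compound is compound 4 `Brc1ccccc1CSc1nnc(-c2ccc3c(c2)OCCO3)n1-c1ccccc1`, which has 2-bromophenyl in place of 4-methylphenyl at the same place: 2-bromophenyl in place of 4-methylphenyl on a saturated chain carbon bound to a sulfur. Among the measured compounds shown here, no compound with bromine has been measured yet, so the nearest guide is compound 2 at 970 nM, which carries 2-chlorophenyl. Both large steps in this small set involve that compound: a 51-fold lower number from compound 1 to compound 2 (1.71 log units; beyond the scatter), and again a 59-fold higher number from compound 2 to compound 3 (1.77 log units; beyond the scatter). A large step towards a lower number is therefore expected in this assay, though perhaps a somewhat smaller one, since a single compound is thin support. The expected change is a 38-fold lower number from compound 3 to compound 4 (1.58 log units; beyond the scatter). Compound 4 is estimated at 1500 nM, with an expected range from 350 nM to 9000 nM.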

Compound 4, half-maximal inhibitory concentration: 4730 nM
Beside the measured number, compound 4's estimate is 3.2-fold (0.50 log units) below it; the measured number falls inside the stated range.
By their numbers in this assay, from the lowest: compound 2; then compound 4; then compounds 1 and 3 (each within the scatter of the next).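

In this assay, the low number of compound 2 no longer stands alone: 2-bromophenyl on a saturated chain carbon bound to a sulfur also lies well clear of the two high compounds, with a 12-fold lower number from compound 3 to compound 4 (1.08 log units; beyond the scatter) and a 10-fold lower number from compound 1 to compound 4 (1.02 log units; beyond the scatter). The choice of halogen still matters here, since bromo in place of chloro on an aromatic carbon gives a 4.9-fold higher number from compound 2 to compound 4 (0.69 log units; beyond the scatter), which leaves 2-chlorophenyl as the group with the lowest number of the four. No measurement shown here explains why these groups differ so much.

The compounds shown leave open whether the low numbers depend on the halogen itself or on where it sits on the ring, as 2-chlorophenyl and 2-bromophenyl share both features while 3-nitrophenyl and 4-methylphenyl share neither. A 2-methylphenyl or 4-chlorophenyl group would separate these two readings, and 2-fluorophenyl would show whether the step from chloro to bromo continues in the other direction.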